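The source may report more compounds than this note shows. Statements on the series, on what has been measured and on what is new or still open speak of the compounds shown alone.

Compound 3 (`Cc1c(Cl)ccc2c1NC(=O)C2(c1ccc(O)cc1)C1CCCCCC1`) belongs to a small set tested in a functional assay on MCF7 cells (Homo sapiens) for cytotoxicity, read by WST assay, with a stated time of 72 h (a lower number here means a stronger inhibitor, a higher number a weaker inhibitor), and gives 51 nM there. Compound 1 (`O=C1Nc2c(ccc(F)c2F)C1(c1ccc(O)cc1)c1ccc(F)cc1`) gives 2.6 nM in the same test, so compound 3 has the higher of the two true numbers and is the weaker inhibitor of that pair. Compound 2 (`CCCC1(c2ccc(O)cc2)C(=O)Nc2c1ccc(F)c2F`) gives > 1000 nM as its result, which is a limit of the assay and not a number.

Compound 4 (`COc1ccc2c(c1C)NC(=O)C2(c1ccc(O)cc1)C1CCCCCC1`) differs from compound 3 in one group, with methoxy in place of chloro on an aromatic carbon. That carbon is ortho to a methyl group.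

For the measured compounds named here, only one measured step can be set beside this change, and it concerns a different kind of place: propyl in place of 4-fluorophenyl on a saturated ring carbon gives an at least 380-fold higher number from compound 1 to compound 2 (2.58 log units; beyond the scatter) as a large step. It shows that a single change can matter a great deal in this set, but it says nothing direct about the group on the aromatic carbon. Going by the values given here, no step has been measured at that place, so only a modest shift is expected in this assay, and its direction is uncertain. As an estimate, the expected step is a 1.6-fold higher number from compound 3 to compound 4 (0.20 log units; within the scatter) and no clear change is assumed. For compound 4 the estimated value is 80 nM with an expected range from 20 nM to 320 nM as the likely span.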

Compound 4, half-maximal inhibitory concentration: 4.7 nM
The estimate for compound 4 lay 17-fold (1.23 log units) above the measured number; the whole stated range lies above it.
By their numbers in this assay, from the lowest: compounds 1 and 4 (each within the scatter of the next); then compound 3. At a limit, above all of these: compound 2.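

In this assay, methoxy in place of chloro on this aromatic carbon, ortho to a methyl group, gives an 11-fold lower number from compound 3 to compound 4 (1.04 log units; beyond the scatter) and so makes compound 4 the stronger inhibitor of the pair. For the compounds shown here, the only step available earlier concerned a saturated ring carbon, so this is the first sign that the aromatic position also matters: swapping one small group for another here moves the result well beyond the scatter, and it does so towards a stronger inhibitor. The data shown hold nothing that accounts for the direction or size of this step, and a single pair cannot separate the loss of chloro from the arrival of methoxy.

As far as these compounds go, only these two groups can be compared at this carbon, so it remains open whether an amine, a hydroxyl group or a longer ether such as ethoxy would give a number nearer to that of compound 4 or to that of compound 3. From the compounds shown here alone, it is also open whether the same swap would have a similar effect without the neighbouring methyl group, or with a group other than the large saturated ring that compounds 3 and 4 share.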